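Substitution on the ring amide nitrogen: compound 2 to compound 3

The source may hold more compounds than are shown below. What is called first, only, known or untested is meant among the compounds shown, and "the series" means these compounds.

Measured so far:
compound 1 `CCc1cnc(N2CCC(c3nc(COc4ccc(/C=C5\CC(=O)NC5=O)cc4F)cs3)CC2)nc1` — 49 nM
compound 2 `CCc1cnc(N2CCC(c3nc(COc4ccc(/C=C5\CC(=O)N(c6ccccc6)C5=O)cc4F)cs3)CC2)nc1` — 82 nM

In a functional assay on cells for agonist activity at Glucose-dependent insulinotropic receptor (Homo sapiens), read by a luciferase reporter, with a stated time of 6 h (on this read-out lower numbers stand for an effect already at smaller amounts and higher numbers for an effect only at larger amounts of compound), compound 1 gives 49 nM and compound 2 gives 82 nM. The two numbers lie within the scatter of each other: a 1.7-fold higher number from compound 1 to compound 2 (0.22 log units; within the scatter). On the numbers shown, compound 2 therefore sits beside compound 1 with no separation that can be read.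

Compound 3 `CCc1cnc(N2CCC(c3nc(COc4ccc(/C=C5\CC(=O)N(CC6CCOCC6)C5=O)cc4F)cs3)CC2)nc1` carries the change ((oxan-4-yl)methyl in place of phenyl on an amide-type nitrogen in a ring). Among the compounds with values here, the only measured step that touches this ring nitrogen is a 1.7-fold higher number from compound 1 to compound 2 (0.22 log units; within the scatter), which placed phenyl there without any effect beyond the scatter. Within the data shown here, no measured step brings in the (oxan-4-yl)methyl group, so the entering group itself has no precedent.

Among the measured compounds shown here, with the one relevant step lying within the scatter, no step beyond the scatter is expected in this assay for compound 3, in either direction: a 1.0-fold lower number from compound 2 to compound 3 (0.01 log units; within the scatter). Compound 3 is estimated at 80 nM in this assay, with a range from 35 nM to 200 nM.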

Compound 3, half-maximal effective concentration: 240 nM
Compound 3: the middle estimate sits 3.0-fold (0.48 log units) below what was measured; the measured number lies above the stated range.
By their numbers in this assay, from the lowest: compounds 1 and 2 (each within the scatter of the next); then compound 3.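

Substitution on this amide-type nitrogen is not neutral in every case. In this assay, within the data shown here, the (oxan-4-yl)methyl group gives the first steps at this position that lie beyond the scatter, both modest (a 2.9-fold higher number from compound 2 to compound 3 (0.47 log units; beyond the scatter); a 4.9-fold higher number from compound 1 to compound 3 (0.69 log units; beyond the scatter)), whereas phenyl in place of hydrogen stayed within it. The outcome therefore follows the identity of the group and not merely the presence of a substituent on the nitrogen, and no measurement at hand accounts for the difference between the two groups.

The step from phenyl to (oxan-4-yl)methyl changes several things at once: an aromatic ring of carbon only gives way to a non-aromatic ring with a hetero atom, a hydrogen-bond acceptor enters, and a methyl link now stands between the ring and the nitrogen, so these three compounds cannot show which of these changes goes with the higher number. Benzyl on the same nitrogen would keep the aromatic ring with the methyl link, cyclohexylmethyl would keep the non-aromatic ring without the oxygen, and together they would leave open only how a longer chain or an amine at this place would read.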